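Methoxy Extension on the Carbamate Side Chain

The source may hold more compounds than are shown below. What is called first, only, known or untested is meant among the compounds shown, and "the series" means these compounds.

Measured compounds:
compound 1, `CC1=C(N2CC2)C(=O)C(Cc2ccccc2)=C(N2CC2)C1=O`: 4.69
compound 2, `CCOC(COC(N)=O)C1=C(N2CC2)C(=O)C(C)=C(N2CC2)C1=O`: 5.22
compound 3, `COCCC1=C(N2CC2)C(=O)C(CCOC)=C(N2CC2)C1=O`: 5.31

Of the compounds shown here, three sharing one core have been measured in a functional assay on L1210 cells (Mus musculus), with a stated time of 12 days; a lower number here means a less potent compound, a higher number a more potent compound, by a factor of ten per unit of this negative logarithm. Compound 2 stands second highest of the three. Its nearest neighbour is compound 3, whose value lies within the scatter of that of compound 2, so the two cannot be told apart. Compound 1 lies furthest away, beyond the scatter and lower than compound 2.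

The next compound, compound 4 `COCCOC(COC(N)=O)C1=C(N2CC2)C(=O)C(C)=C(N2CC2)C1=O`, differs from compound 2 in one place: methoxy in place of hydrogen on a saturated chain carbon, two bonds along the chain from an oxygen on a saturated carbon. Among the measured compounds shown here, no step between measured compounds of this kind is on record, so the direction of this change in this assay is open. Given that compound 3, which also carries methoxy-terminated chains, sits within the scatter of compound 2, the step is expected to be small in this assay, most likely not beyond the scatter in either direction. The expected step is a number 0.08 log units higher from compound 2 to compound 4 (within the scatter). Compound 4 is therefore estimated at 5.3, with a range from 4.8 to 5.8.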

Compound 4, logarithm of the reciprocal of the active concentration, log(1/C): 5.39
Beside the measured number, compound 4's estimate is 0.09 log units below it, and the stated range covers the measured number.
By their numbers in this assay, from the lowest: compound 1; then compounds 2, 3 and 4 (each within the scatter of the next).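

In this assay, among the compounds shown here, the change from ethoxy to 2-methoxyethoxy gives a number 0.17 log units higher from compound 2 to compound 4 (within the scatter) and is the first step on record for methoxy in place of hydrogen on a saturated chain carbon, two bonds along the chain from an oxygen on a saturated carbon. Compound 2 and compound 4 cannot be told apart, so this position takes the added methoxy without a difference that this read-out can resolve. Nothing available offers an explanation for this result.

A single step cannot show whether methoxy in place of hydrogen would behave in the same way on another chain of the shared core. As far as these compounds go, it also remains open how this position would respond if an amine, a carboxylic acid or a longer chain stood in place of the methoxy.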